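Acyl triazene series: acetoxyacetyl replacement on compound 3

The compounds below may be only part of what the source reports. "The series", "measured", "known", "first", "only" and "open" are said of these compounds alone.

Among the compounds with values here, compound 3 `O=C(c1ccccc1C(F)(F)F)N(/N=N/c1ccc([N+](=O)[O-])cc1Br)c1ccc([N+](=O)[O-])cc1Br` gives 13300 nM in a functional assay on HeLa cells (Homo sapiens) for cytotoxicity, read by MTT assay, with a stated time of 72 h (a higher number here means a weaker inhibitor, a lower number a stronger inhibitor), the highest of the three numbers so far; compound 2 `O=C(c1ccccc1F)N(/N=N/c1ccc([N+](=O)[O-])cc1Br)c1ccc([N+](=O)[O-])cc1Br` gives 1200 nM and compound 1 `O=[N+]([O-])c1ccc(/N=N/Nc2ccc([N+](=O)[O-])cc2Br)c(Br)c1` gives 940 nM. Two steps are in hand: a 1.3-fold higher number from compound 1 to compound 2 (0.11 log units; within the scatter); an 11-fold higher number from compound 2 to compound 3 (1.04 log units; beyond the scatter). Compound 4 `CC(=O)OCC(=O)N(/N=N/c1ccc([N+](=O)[O-])cc1Br)c1ccc([N+](=O)[O-])cc1Br` carries acetoxymethyl in place of 2-(trifluoromethyl)phenyl on a carbonyl carbon. The second step bears on this most directly, because an 11-fold higher number from compound 2 to compound 3 (1.04 log units; beyond the scatter) shows that the group on the carbonyl carbon moves the number strongly, while a 1.3-fold higher number from compound 1 to compound 2 (0.11 log units; within the scatter) shows that acylation alone changes little. Within the data shown here, no measured compound carries acetoxymethyl, so the expectation rests only on removing 2-(trifluoromethyl)phenyl. Compound 4 is therefore expected to give 2000 nM (range 600 nM to 7000 nM), an estimated step of a 6.7-fold lower number from compound 3 to compound 4 (0.82 log units; beyond the scatter) back toward the earlier numbers.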

Compound 4, half-maximal inhibitory concentration: 490 nM
Estimate against measurement, compound 4: 4.1-fold (0.61 log units) above; measured number below the stated range.
By their numbers in this assay, from the lowest: compounds 4, 1 and 2 (each within the scatter of the next, the first and the last beyond it); then compound 3.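

In this assay, the group on the carbonyl carbon spans a wide range without any aromatic ring being needed there: a 27-fold lower number from compound 3 to compound 4 (1.43 log units; beyond the scatter) on exchanging 2-(trifluoromethyl)phenyl for acetoxymethyl, and a 2.4-fold lower number from compound 2 to compound 4 (0.39 log units; beyond the scatter) on exchanging 2-fluorophenyl for it. With this group, acylation leaves the number within the scatter, with a 1.9-fold lower number from compound 1 to compound 4 (0.28 log units; within the scatter) as the step. Nothing at hand explains these steps. Still open, on these data alone, is whether the ester itself matters: a hydroxymethyl, a carboxylic acid or a longer acyloxyalkyl chain on the carbonyl carbon would test this.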